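This account rests on a few compounds, and the source may have more. Where it says the series, first, only, none or still open, it means among the compounds named here.

Measured in a functional assay on MDA-MB-231 cells (Homo sapiens) for cytotoxicity, read by sulforhodamine B assay, with a stated time of 72 h; on this read-out higher numbers stand for weaker inhibition of growth and lower numbers for stronger inhibition of growth:

compound 1, `O=C(Nc1ccccc1O)C1CCc2ccccc2N1C(=O)c1ccccc1Cl`, gives 47400 nM
compound 2, `O=C(Nc1ccccc1O)C1CCc2ccccc2N1C(=O)c1ccc(Cl)cc1`, gives 19600 nM
compound 3, `CCCCCCCCC(=O)N1c2ccccc2CCC1C(=O)Nc1ccccc1O`, gives 54300 nM

Compound 3 has the highest number of the three, meaning the weakest growth inhibition, though its gap to compound 1 lies within the scatter, so the two cannot be ordered; only compound 2 is clearly separated from it. Compound 4, `O=C(Nc1ccccc1O)C1CCc2ccccc2N1C(=O)c1cccc(Cl)c1`, differs from compound 3 by 3-chlorophenyl in place of octyl on a carbonyl carbon. Among the compounds with values here, two measured steps bear on this exchange of the octyl chain for a chlorine-bearing ring at the same carbonyl. In the direction measured, a 1.1-fold higher number from compound 1 to compound 3 (0.06 log units; within the scatter), so a chlorophenyl and an octyl there were equivalent, while a 2.8-fold higher number from compound 2 to compound 3 (0.44 log units; beyond the scatter), so the other chlorophenyl placement was modestly better than octyl. A chlorophenyl with the chlorine at the third position has no direct comparison here, but both precedents suggest the ring will be no worse than octyl, and one suggests a modest gain. A modest decrease in this assay is therefore expected, a 1.8-fold lower number from compound 3 to compound 4 (0.26 log units; within the scatter). Compound 4 is estimated at 30000 nM, with a range from 13000 nM to 65000 nM.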

Compound 4, concentration for 50% growth inhibition: 10600 nM
For compound 4 the middle estimate is 2.8-fold (0.45 log units) above the measured one; measured number below the stated range.
By their numbers in this assay, from the lowest: compounds 4 and 2 (each within the scatter of the next); then compounds 1 and 3 (each within the scatter of the next).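

In this assay, a chlorophenyl ring on this carbonyl carbon is not automatically better than the octyl chain: the 3-chlorophenyl ring clearly beats octyl (a 5.1-fold lower number from compound 3 to compound 4 (0.71 log units; beyond the scatter)) and also the 2-chlorophenyl ring (a 4.5-fold lower number from compound 1 to compound 4 (0.65 log units; beyond the scatter)). Exchanging the 4-chlorophenyl ring for the 3-chlorophenyl ring gives a step within the scatter (a 1.8-fold lower number from compound 2 to compound 4 (0.27 log units; within the scatter)), so these two rings cannot be ordered, and only the 2-chlorophenyl ring stays level with octyl. No supporting measurement is available to explain why the 2-chlorophenyl ring sets itself apart from the other two.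

From the compounds shown here alone, whether chlorine itself matters remains open, since an unsubstituted phenyl ring or a methoxy-bearing or amine-bearing ring could perform differently. A shorter chain than octyl, or one ending in a carboxylic acid, is also untested among these compounds.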